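Swapping Methyl for Fluorine on the Benzyl Group

A few compounds are considered here, and "the series" means these few. Any claim that something is new, unique, unknown or untested is made for them only; others in the source may bear on it.

Measured compounds:
compound 1, `O=C(/C=C/c1ccc(OCc2nc(C3CCN(Cc4ccccc4)CC3)no2)cc1)NO`, 71%
compound 2, `Cc1cccc(CN2CCC(c3noc(COc4ccc(/C=C/C(=O)NO)cc4)n3)CC2)c1`, 73%
compound 3, `Cc1ccc(CN2CCC(c3noc(COc4ccc(/C=C/C(=O)NO)cc4)n3)CC2)cc1`, 76%

In an assay on isolated protein for inhibition of protein deacetylase HDAC6 (Homo sapiens), read by fluorescence, with a stated time of 1 h, tested at 100 nM (on this read-out higher numbers stand for more inhibition at the one concentration tested (going by the name of the read-out) and lower numbers for less inhibition), compound 3 gives the highest of the three numbers, yet its lead is slight: a number 5 percentage points higher from compound 1 to compound 3 (within the scatter) and a number 3 percentage points higher from compound 2 to compound 3 (within the scatter), both within the scatter. Compound 4, `O=C(/C=C/c1ccc(OCc2nc(C3CCN(Cc4cccc(F)c4)CC3)no2)cc1)NO`, differs from compound 3 by one change: 3-fluorophenyl in place of 4-methylphenyl on a saturated chain carbon bound to an amine nitrogen in a ring. Among the measured compounds shown here, three measured steps bear on it. Adding a methyl to the ring gave a number 2 percentage points higher from compound 1 to compound 2 (within the scatter) and a number 5 percentage points higher from compound 1 to compound 3 (within the scatter); moving it gave a number 3 percentage points higher from compound 2 to compound 3 (within the scatter). None left the scatter, so this exchange on the same ring is expected to give no step beyond it: a number 4 percentage points lower from compound 3 to compound 4 (within the scatter). Compound 4 is therefore estimated at 72%, within 60% to 84%.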

Compound 4, a percentage reported as inhibition, at one concentration (the size of the read-out at that concentration, not a potency): 73%
The estimate for compound 4 lay 1 percentage points below the measured number; the measured number falls inside the stated range.
By their numbers in this assay, from the lowest: compounds 1, 2, 4 and 3 (each within the scatter of the next).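

In this assay, fluoro on this benzyl ring gives no step beyond the scatter, whether it is compared with 4-methylphenyl (a number 3 percentage points lower from compound 3 to compound 4 (within the scatter)), with 3-methylphenyl, as fluoro in place of methyl (no change at the digits printed from compound 2 to compound 4 (within the scatter)), or with the bare ring, as fluoro in place of hydrogen (a number 2 percentage points higher from compound 1 to compound 4 (within the scatter)). So at this place, a halogen joins methyl among the groups that leave the number within the scatter. Nothing at hand offers an explanation for this result.

On these data alone, whether a carboxylic acid or an amine on this ring would move the number beyond the scatter remains open. So does the outcome of replacing the benzyl group with a longer chain.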